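This account rests on a few compounds, and the source may have more. Where it says the series, first, only, none or still open, it means among the compounds named here.

Measured compounds in a functional assay on MCF7 cells (Homo sapiens) for inhibition, read by MTT assay, with a stated time of 24 h; a higher number here means a weaker inhibitor, a lower number a stronger inhibitor:
- compound 1 `CCCCCCCCn1cc(COC2(C(F)(F)F)Oc3ccccc3C=C2C(=O)OCC)nn1`: > 150000 nM
- compound 2 `CCOC(=O)C1=Cc2ccccc2OC1(OCc1cn(-c2cccc(C(F)(F)F)c2)nn1)C(F)(F)F`: > 150000 nM

Both values are limits of this assay, not numbers. Compound 1 gives > 150000 nM in this assay, a limit. Compound 2 gives > 150000 nM in this assay, likewise a limit. The only measured step, a step that the two limits leave unreadable from compound 1 to compound 2, is therefore unreadable because both of its ends sit at the limit of > 150000 nM in this assay, at which 2 of the 2 values shown sit; where compound 2 stands on the numbers shown is thus known only as a limit, with no ranking against compound 1 possible.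

Compound 3 `CCOC(=O)C1=Cc2ccccc2OC1(OCc1cn(-c2ccc(C)cc2)nn1)C(F)(F)F` has not yet been measured in this assay. Relative to compound 2 the change is 4-methylphenyl in place of 3-(trifluoromethyl)phenyl on an aromatic nitrogen. Among the measured compounds shown here, the one measured step touches the same position on the aromatic nitrogen, but it gives no readable size, so no direction can be drawn from it. With both measured compounds at the limit, compound 3 is expected to stay near that limit as well, and a numerical value is more likely to be missing than present. Compound 3 is expected at 200000 nM, with a range from 60000 nM to 700000 nM. The step that the limit leaves unreadable from compound 2 to compound 3 is expected to be none beyond the scatter.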

Compound 3, half-maximal inhibitory concentration: 26700 nM
Beside the measured number, compound 3's estimate is 7.5-fold (0.87 log units) above it; the whole stated range lies above it.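

In this assay, the aromatic nitrogen of the five-membered ring proves to be a position where the group can move the read-out: 4-methylphenyl in place of 3-(trifluoromethyl)phenyl gives an at least 5.6-fold lower number from compound 2 to compound 3 (0.74 log units; beyond the scatter), the first readable change in the series. 4-Methylphenyl in place of octyl gives an at least 5.6-fold lower number from compound 1 to compound 3 (0.74 log units; beyond the scatter), so among the three groups shown at this nitrogen, only 4-methylphenyl gives a numerical value. The full size of both steps remains unknown, since each has a limit at one end: the limit of > 150000 nM in this assay, at which 2 of the 3 values shown sit.

The compounds shown do not separate a contribution of the methyl group from that of losing the trifluoromethyl group or of the change in substitution pattern, and a plain phenyl, a 3-methylphenyl or a 4-(trifluoromethyl)phenyl on the same nitrogen would bear on that question. Also open, as far as these compounds go, is how an aryl group carrying an amine or a carboxylic acid, or a chain shorter than octyl, would read at this nitrogen, while the step between the two compounds at the limit cannot be read and leaves them unranked.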